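Imine Aryl Swap in a Methylsulfonyl Triazole Thione Series

The source may report more compounds than this note shows. Statements on the series, on what has been measured and on what is new or still open speak of the compounds shown alone.

Compound 1, `CS(=O)(=O)c1ccc(Cc2n[nH]c(=S)n2/N=C/c2ccc(Cl)cc2)cc1`, gives 57% in a functional assay on HeLa cells (Homo sapiens) for cytotoxicity, read by MTT assay, with a stated time of 48 h, tested at 100 uM; a higher number here means a stronger effect of the compound at the concentration tested, a lower number a weaker effect. Compound 2, `CS(=O)(=O)c1ccc(Cc2n[nH]c(=S)n2/N=C/c2ccccc2F)cc1`, gives 28.1% in this assay.

Compound 2 stands lowest of the two numbers shown; its nearest neighbour is compound 1, and the move between them is a number 28.9 percentage points lower from compound 1 to compound 2 (beyond the scatter). Compound 3, `CS(=O)(=O)c1ccc(Cc2n[nH]c(=S)n2/N=C/c2cccnc2)cc1`, is not yet measured; it differs from compound 2 thus: pyridin-3-yl in place of 2-fluorophenyl on a carbon with a double bond to nitrogen.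

Among the measured compounds shown here, only one measured step bears on this change, the one from compound 1 to compound 2, which exchanged one group on the same carbon with a double bond to nitrogen and gave a number 28.9 percentage points lower from compound 1 to compound 2 (beyond the scatter). That step swapped one carbon-only ring for another, whereas here a ring with a hetero atom enters, so the data give no direct guide on direction. A group change at this position has already moved the read-out beyond the scatter once, so a step of similar size in either direction is plausible, and the estimate is centred between the two measured values.

For compound 3 in this assay the expected value is 40%, in a range from 15% to 65%. The expected step is a number 11.9 percentage points higher from compound 2 to compound 3 (beyond the scatter).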

Compound 3, a percentage reported as activity, at one concentration (the size of the read-out at that concentration, not a potency): 45.1%
Compound 3: middle estimate off by 5.1 percentage points, on the low side; the measured number falls inside the stated range.
By their numbers in this assay, from the lowest: compound 2; then compound 3; then compound 1.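

Placing a ring with a hetero atom on the carbon with a double bond to nitrogen gives a number 17 percentage points higher from compound 2 to compound 3 (beyond the scatter) in this assay, and it also gives a number 11.9 percentage points lower from compound 1 to compound 3 (beyond the scatter). Compound 3 therefore falls between the two compounds with carbon-only rings, and the three groups give three separate levels in this assay, showing that among these compounds the read-out at this position does not simply divide into carbon-only rings on one side and the ring with a hetero atom on the other. No measurement shown here accounts for this order.

The compounds shown leave open how an unsubstituted phenyl ring would compare, and thus whether the 4-chlorophenyl and 2-fluorophenyl groups each raise or lower the read-out relative to it. They also leave open whether pyridin-2-yl or pyridin-4-yl would read like pyridin-3-yl, and how an amine or a carboxylic acid on the ring, or a longer chain in its place, would fit into this order.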